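Pyridin-2-yl in Place of 2-Methylphenyl: An Expected Step

The compounds below may be only part of what the source reports. "The series", "measured", "known", "first", "only" and "open" are said of these compounds alone.

Of the compounds shown here, three have been tested in an assay on isolated protein for inhibition of DNA topoisomerase 1 (Homo sapiens), tested at 100 uM; a lower number here means a weaker effect, a higher number a stronger effect of the compound at the concentration tested. Compound 1 `Clc1ccc(-c2cc(-c3cccnc3)nc(-c3cccs3)c2)o1` gives 25.8%, compound 2 `Cc1ccccc1-c1cc(-c2ccc(Cl)o2)cc(-c2ccsc2)n1` gives 6.7%, and compound 3 `Clc1ccc(-c2cc(-c3ccco3)cc(-c3cccs3)n2)cc1` gives 2.7%. Among these three numbers compound 2 stands second highest; its nearest neighbour is compound 3, whose number is lower by an amount that lies within the usual scatter of repeated measurements, so the two cannot be told apart. Its furthest neighbour is compound 1, whose number is higher by an amount that lies beyond the scatter, so compound 1 is clearly the stronger of that pair.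

The next compound, compound 4 `Clc1ccc(-c2cc(-c3ccsc3)nc(-c3ccccn3)c2)o1`, has not yet been measured. It differs from compound 2 in one place: pyridin-2-yl in place of 2-methylphenyl on an aromatic carbon.

Among the measured compounds shown here, no pair of measured compounds differing in a single place has been compared, so the size of this step is uncertain. A modest rise is expected for compound 4 in this assay, because compound 1 shows with 25.8% that numbers of this size are reached in this series, while compound 2 with 6.7% sets the starting point. The step is expected to be a number 8.3 percentage points higher from compound 2 to compound 4 (within the scatter), possibly still within the scatter. Compound 4 is estimated at 15%, with a range from 3% to 30%.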

Compound 4, a percentage reported as inhibition, at one concentration (the size of the read-out at that concentration, not a potency): 0%
Beside the measured number, compound 4's estimate is 15 percentage points above it; measured number outside the range, below it.
By their numbers in this assay, from the lowest: compounds 4, 3 and 2 (each within the scatter of the next); then compound 1.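

Among the compounds shown here, at this position, on an aromatic carbon next to the ring nitrogen, putting pyridin-2-yl in place of 2-methylphenyl gives a number 6.7 percentage points lower from compound 2 to compound 4 (within the scatter) in this assay and is the only single-place comparison available in this set. The exchange replaces a ring of carbon only with a ring holding one nitrogen and one hydrogen-bond acceptor, yet the two compounds cannot be told apart at the concentration tested, so this change shows no readable effect here. Nothing measured on these compounds offers an explanation for this result.

As far as these compounds go, compound 1 reaches 25.8% but differs from the other compounds in more than one place, so its steps to them cannot be read, and which of its groups matter remains unknown. Also open, from the compounds shown here alone, is whether a quite different group at this position, such as an amine, a carboxylic acid or a longer chain, would move the number beyond the usual scatter of repeated measurements.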